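The source may report more compounds than this note shows. Statements on the series, on what has been measured and on what is new or still open speak of the compounds shown alone.

Measured in a functional assay on HeLa S3 cells (Homo sapiens) for antiproliferative activity, read by XTT assay, with a stated time of 72 h; a higher number here means a weaker inhibitor, a lower number a stronger inhibitor:
compound 1 `COc1ncnc2c1c(-c1ccsc1)cn2[C@@H]1O[C@H](CO)[C@@H](O)[C@H]1O` gives 3350 nM.
compound 2 `COc1ncnc2c1c(-c1ccoc1)cn2[C@@H]1O[C@H](CO)[C@@H](O)[C@H]1O` gives 1790 nM.
compound 3 `COc1nc(N)nc2c1c(-c1ccoc1)cn2[C@@H]1O[C@H](CO)[C@@H](O)[C@H]1O` gives only a limit, > 20000 nM; see (the limit of > 20000 nM in this assay, at which 1 of the 3 values shown sits).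

Compound 2 stands lowest of the two numbers given, with compound 1 nearest: a 1.9-fold lower number from compound 1 to compound 2 (0.27 log units; within the scatter). The step of an at least 11-fold higher number from compound 2 to compound 3 (1.04 log units; beyond the scatter) is large but concerns a different position. Compound 4 `CSc1ncnc2c1c(-c1ccoc1)cn2[C@@H]1O[C@H](CO)[C@@H](O)[C@H]1O` differs from compound 2 by methylsulfanyl in place of methoxy on an aromatic carbon. Among the measured compounds shown here, no measured step touches this position; the only comparable heteroatom swap, furan-3-yl in place of thiophen-3-yl, stayed within the scatter, so in this assay a step of modest size, if any, is expected. For compound 4 the estimated value is 2500 nM, with a range of 800 nM to 8000 nM. This estimate means a 1.4-fold higher number from compound 2 to compound 4 (0.15 log units; within the scatter).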

Compound 4, half-maximal inhibitory concentration: 5390 nM
Estimate against measurement, compound 4: 2.2-fold (0.33 log units) below, within the range that was stated.
By their numbers in this assay, from the lowest: compounds 2, 1 and 4 (each within the scatter of the next, the first and the last beyond it). At a limit, above all of these: compound 3.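

In this assay, among the compounds shown here, methylsulfanyl in place of methoxy gives a 3.0-fold higher number from compound 2 to compound 4 (0.48 log units; beyond the scatter) and is the only measured change at this position, next to the ring nitrogen. The position therefore responds to this exchange, although the size of the step is modest. The swap of furan-3-yl for thiophen-3-yl had stayed within the scatter, so a swap of the same two heteroatoms does not read alike at both places. Nothing shown bears on the cause of this step. Open questions are how an amine or a longer chain such as ethoxy would read at this carbon, and whether the step holds with thiophen-3-yl in place of furan-3-yl.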